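Allyloxy in place of allyl on compound 3

This account rests on a few compounds, and the source may have more. Where it says the series, first, only, none or still open, it means among the compounds named here.

In a functional assay on A549 cells (Homo sapiens) for inhibition, read by colorimetric assay and MTT assay, with a stated time of 72 h (a higher number here means a weaker inhibitor, a lower number a stronger inhibitor), compound 1 `C=CCCCCOc1ccc(F)cc1-c1cnc(OCCC=C)n1C` gives 61000 nM and compound 2 `C=CCCCCOc1cc(F)ccc1-c1cnc(OCCC=C)n1C` gives 74000 nM while compound 3 `C=CCCCCOc1ccccc1-c1cnc(OCCCC=C)n1C` gives 3000 nM as the lowest of the three numbers, beyond the scatter from both. The change allyloxy in place of allyl on a saturated chain carbon, two bonds along the chain from an oxygen on an aromatic ring turns compound 3 into compound 4 `C=CCCCCOc1ccccc1-c1cnc(OCCOCC=C)n1C` with allyloxy in place of allyl on a saturated chain carbon, two bonds along the chain from an oxygen on an aromatic ring. Within the data shown here, no measured pair shows this change, so the expectation starts from compound 3 at 3000 nM and is a modest move in this assay toward a weaker inhibitor, near the edge of the scatter. The estimate means a 2.0-fold higher number from compound 3 to compound 4 (0.30 log units; within the scatter) as the expected step. For compound 4 the estimated value is 6000 nM with an expected range of 2000 nM to 20000 nM for now.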

Compound 4, half-maximal inhibitory concentration: 34000 nM
For compound 4 the middle estimate is 5.7-fold (0.75 log units) below the measured one; the whole stated range lies below it.
By their numbers in this assay, from the lowest: compound 3; then compounds 4, 1 and 2 (each within the scatter of the next, the first and the last beyond it).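

In this assay, among these compounds, allyloxy in place of allyl gives an 11-fold higher number from compound 3 to compound 4 (1.05 log units; beyond the scatter), the only single-place comparison so far and one beyond the scatter. This saturated chain carbon, two bonds along the chain from an oxygen on an aromatic ring, is therefore sensitive to this change, which adds one hydrogen-bond acceptor by count. No measured evidence accounts for the size of the step.

Going by these compounds, whether the loss follows the added oxygen or the added length remains open. A longer all-carbon chain or an amine at this place could separate the two.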